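The compounds below may be only part of what the source reports. "The series", "measured", "known", "first", "only" and "open" are said of these compounds alone.

Working notes on the series.

Compound 1 `CN(Cc1cccc(C(=O)O)c1)c1ccc(OCc2c(-c3c(Cl)cccc3Cl)noc2C2CC2)nc1C(F)(F)F` gives in a functional assay on HEK293 cells for agonist activity at Bile acid receptor (Homo sapiens) (a lower number here means a smaller maximal response, a higher number a larger maximal response), a value of 79%. Compound 2 `CN(Cc1ccc(C(=O)O)cc1)c1ccc(OCc2c(-c3c(Cl)cccc3Cl)noc2C2CC2)nc1C(F)(F)F` gives in this assay a value of 81%; the step of a number 2 percentage points higher from compound 1 to compound 2 (within the scatter) shows that moving the carboxyl from the 3- to the 4-position on this benzyl group leaves the maximal response unchanged. Compound 3 `CC(Nc1ccc(C(=O)O)cc1)c1ccc(OCc2c(-c3c(Cl)cccc3Cl)noc2C2CC2)nc1C(F)(F)F` gives in this assay a value of 59%, the lowest of the three numbers; the steps of a number 20 percentage points lower from compound 1 to compound 3 (beyond the scatter) and a number 22 percentage points lower from compound 2 to compound 3 (beyond the scatter) are both modest decreases beyond the scatter.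

Compound 4 `O=C(O)c1ccccc1OCc1ccc(OCc2c(-c3c(Cl)cccc3Cl)noc2C2CC2)nc1C(F)(F)F` has not yet been measured in this assay. Its difference from compound 3 is (2-carboxyphenoxy)methyl in place of 1-((4-carboxyphenyl)amino)ethyl on an aromatic carbon. For the measured compounds named here, no measured step matches this exchange; the two steps that bear on it, both into compound 3, show that altering the group on this aromatic carbon can move the maximal response by a modest amount, while the carboxyl shift in the step from compound 1 to compound 2 did not. The direction for compound 4 is therefore open; the expectation is a value somewhere between the level of compound 3 and that of compounds 1 and 2, with a step of a number 9 percentage points higher from compound 3 to compound 4 (within the scatter) estimated. Compound 4 is accordingly expected to give about 68% in this assay, estimated between 48% and 88%.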

Compound 4, largest response reached (reported as efficacy), in percent of the reference or control that the assay uses: 63%
Compound 4: middle estimate off by 5 percentage points, on the high side, within the range that was stated.
By their numbers in this assay, from the lowest: compounds 3 and 4 (each within the scatter of the next); then compounds 1 and 2 (each within the scatter of the next).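

In this assay, the step of a number 4 percentage points higher from compound 3 to compound 4 (within the scatter) shows that (2-carboxyphenoxy)methyl and 1-((4-carboxyphenyl)amino)ethyl cannot be told apart at this aromatic carbon, although the entering group carries no nitrogen and places its carboxyl differently on the benzene ring. The steps of a number 16 percentage points lower from compound 1 to compound 4 (beyond the scatter) and a number 18 percentage points lower from compound 2 to compound 4 (beyond the scatter) show that compound 4 also falls short of both compounds bearing a carboxybenzyl(methyl)amino group, so among these four compounds only those two groups reach the higher maximal response, and no compound goes against this. No supporting data are available to explain this difference between the groups at this position.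

As far as these compounds go, what remains open is whether the shortfall of compound 4 belongs to its oxygen-containing link or to the position of its carboxyl, which a (4-carboxyphenoxy)methyl group would help to separate. From the compounds shown here alone, it is also open whether the higher level of compound 1 and compound 2 depends on the methyl on the amine nitrogen, and whether a tetrazole could stand in place of the carboxylic acid at this position.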